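Chloro on the benzyl group of compound 2

This account rests on a few compounds, and the source may have more. Where it says the series, first, only, none or still open, it means among the compounds named here.

In a functional assay on a cell-free system (plasma, Oryctolagus cuniculus) for inhibition, with stated times of 5 min, 1 min and 6 min (on this read-out higher numbers stand for weaker inhibition and lower numbers for stronger inhibition), compound 1 `CCOC(=O)c1c(C)nc(-c2cccc(C#N)c2)n1OC(C)C` gives 6740 nM and compound 2 `CCOC(=O)c1c(C)nc(-c2cccc(C#N)c2)n1OCc1ccccc1` gives 5930 nM. Among the compounds with values here, these are the only two numbers so far, and they lie within the scatter of each other, so compound 2 stands level with compound 1.

Compound 3 `CCOC(=O)c1c(C)nc(-c2cccc(C#N)c2)n1OCc1ccc(Cl)cc1` differs from compound 2 by chloro in place of hydrogen on an aromatic carbon. This is chloro in place of hydrogen on an aromatic carbon, para to a large group, turning benzyl into 4-chlorobenzyl.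

Within the data shown here, only one measured step bears on this change, and only loosely: benzyl in place of isopropyl on the same oxygen, a 1.1-fold lower number from compound 1 to compound 2 (0.06 log units; within the scatter). Among the measured compounds shown here, no measured compound carries chloro, so the effect of this change has not been tested directly. For the measured compounds named here, with that single small step as the only guide, no change beyond the scatter is expected in this assay, and the expected result is a 1.2-fold lower number from compound 2 to compound 3 (0.07 log units; within the scatter). The evidence is thin, so the range is kept wide. Compound 3 is estimated at 5000 nM, with an expected range of 1800 nM to 13000 nM.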

Compound 3, half-maximal inhibitory concentration: 6830 nM
Compound 3: the middle estimate sits 1.4-fold (0.14 log units) below what was measured; the range from low to high includes it.
By their numbers in this assay, from the lowest: compounds 2, 1 and 3 (each within the scatter of the next).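

In this assay, chloro on the aromatic carbon of the benzyl group gives a 1.2-fold higher number from compound 2 to compound 3 (0.06 log units; within the scatter), so 4-chlorobenzyl stands level with benzyl, and adding a substituent to this ring has not moved the read-out beyond the scatter. Against isopropyl on the same oxygen, 4-chlorobenzyl gives a 1.0-fold higher number from compound 1 to compound 3 (0.01 log units; within the scatter), so isopropyl, benzyl and 4-chlorobenzyl all stand level with one another, and this position has so far tolerated three different groups with no separation in the numbers. No independent measurement on these compounds bears on this result.

As far as these compounds go, whether an amine or a carboxylic acid on the benzyl group, or a longer chain on the oxygen, would carry the number beyond the scatter stays open. The nitrile and the ethyl ester are the same in all three compounds, so what either contributes to inhibition in this assay cannot be read from this set.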